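The compounds below may be only part of what the source reports. "The series", "measured", "known", "first", "only" and "open" are said of these compounds alone.

Measured so far in a functional assay on MCF7 cells (Homo sapiens) for inhibition, read by MTT assay, with a stated time of 72 h; on this read-out lower numbers stand for stronger inhibition of growth and higher numbers for weaker inhibition of growth:

- compound 1 `N#C/C(=C\c1c(F)c(F)c(F)c(F)c1F)C(=O)c1ccc[nH]1` gives 23000 nM
- compound 2 `COc1ccc(CNC(=O)/C(C#N)=C/c2cccc3ccccc23)cc1` gives 16000 nM
- compound 3 `N#C/C(=C\c1ccccc1)C(=O)NCc1ccc(Cl)c(Cl)c1` gives 29000 nM

All three compounds share an acrylonitrile motif carrying a nitrile and a carbonyl, and all three give numbers that sit within the usual scatter of one another. Compound 3 has the highest of the three numbers, but its nearest neighbour, compound 1, lies within the scatter, and so does compound 2, the furthest of the three. Among the compounds with values here, on these numbers, then, no compound can be called stronger or weaker than another.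

Compound 4 `COc1ccc(/C=C(\C#N)C(=O)NCc2ccc(Cl)c(Cl)c2)cc1` is the next compound, not yet measured in this assay. It differs from compound 3 in one place: methoxy in place of hydrogen on an aromatic carbon. Within the data shown here, no pair of measured compounds differs by this change alone, so there is no directly comparable step to lean on. Compound 2 does carry a methoxy group on its own aromatic ring, yet it also differs from compound 3 in other places. The value of compound 2, 16000 nM, therefore gives no isolated reading of a methoxy group.

With nothing in the measured set pointing strongly either way, the step expected in this assay is a 1.5-fold lower number from compound 3 to compound 4 (0.16 log units; within the scatter), no larger than the scatter. Compound 4 is therefore estimated at 20000 nM, with a range from 8000 nM to 50000 nM.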

Compound 4, concentration for 50% growth inhibition: 45000 nM
Beside the measured number, compound 4's estimate is 2.3-fold (0.35 log units) below it, and the stated range covers the measured number.
By their numbers in this assay, from the lowest: compounds 2, 1, 3 and 4 (each within the scatter of the next, the first and the last beyond it).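

Within the data shown here, replacing hydrogen with methoxy on an aromatic carbon, para to a large group, turns phenyl into 4-methoxyphenyl, and this gives the first direct reading of a single change: in this assay it produces a 1.6-fold higher number from compound 3 to compound 4 (0.19 log units; within the scatter) and leaves the two compounds indistinguishable. Among these compounds, at this position, on this core, adding a methoxy group therefore has no effect on growth inhibition that can be told apart from ordinary variation between repeated measurements, a point that the earlier compounds, which differ from one another in several places, could not settle. No measurement offered here bears on the result, so it remains an observation without an explanation.

As far as these compounds go, it remains open whether a different group at this position, such as a hydroxyl group, an amine or a carboxylic acid, would move the number beyond the scatter. From the compounds shown here alone, it is also open whether methoxy would behave the same way elsewhere on this ring or on the core of compound 1 or compound 2, where no single-change comparison is available.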